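Replacing 4-chlorobenzyl with 3-(dimethylamino)propyl on a shared core

The source may report more compounds than this note shows. Statements on the series, on what has been measured and on what is new or still open speak of the compounds shown alone.

In a functional assay for inhibition (a higher number here means a weaker inhibitor, a lower number a stronger inhibitor), compound 2 (`CC(C)(C)c1cc(-c2cc(=O)c3ccc(OCc4ccc(Cl)cc4)cc3o2)cc(C(C)(C)C)c1O`) gives 7000 nM as the highest single number of the set. The nearest neighbour is compound 1 (`CC(C)(C)c1cc(-c2cc(=O)c3ccc(OCC(=O)N4CCN(Cc5ccccc5)CC4)cc3o2)cc(C(C)(C)C)c1O`) at 3000 nM, which lies lower, beyond the scatter. Compound 3 (`CC(C)(C)c1cc(-c2cc(=O)c3ccc(OCC(=O)O)cc3o2)cc(C(C)(C)C)c1O`) has no single number, its entries reading 3000 nM; 100 nM (2 entries) without agreement.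

Compound 4 (`CN(C)CCCOc1ccc2c(=O)cc(-c3cc(C(C)(C)C)c(O)c(C(C)(C)C)c3)oc2c1`) keeps the shared core and has yet to be measured in this assay by anyone. Its difference from compound 2 (2-(dimethylamino)ethyl in place of 4-chlorophenyl on a saturated chain carbon bound to an oxygen on an aromatic ring) is 2-(dimethylamino)ethyl in place of 4-chlorophenyl on a saturated chain carbon bound to an oxygen on an aromatic ring.

Going by the values given here, no two measured compounds differ in one place only, so the size of this step can be judged only from the values themselves. Compound 1 at 3000 nM also lacks the 4-chlorophenyl group and stands lower than compound 2, so a move toward a lower number is expected. The estimated step (a 2.3-fold lower number from compound 2 to compound 4 (0.37 log units; beyond the scatter)) would be modest, toward a stronger inhibitor. The expected range is kept wide because of the several entries of compound 3 in this assay, 3000 nM; 100 nM (2 entries) that sit far apart. The estimate for compound 4 is 3000 nM with an expected range from 600 nM to 12000 nM when the measurement arrives.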

Compound 4, half-maximal inhibitory concentration: 700 nM
Beside the measured number, compound 4's estimate is 4.3-fold (0.63 log units) above it; measured number inside the range.
By their numbers in this assay, from the lowest: compound 4; then compound 1; then compound 2.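

In this assay, going by these compounds alone, the change from 4-chlorobenzyl to 3-(dimethylamino)propyl gives a 10-fold lower number from compound 2 to compound 4 (1.00 log units; beyond the scatter) and is the first step in this set that can be read at one place alone. It shows that, at this position on a saturated chain carbon bound to an oxygen on an aromatic ring, the 4-chlorophenyl group is not required for inhibition: with no ring there and a dimethylamino group in its stead, compound 4 is the stronger inhibitor of the pair. This is a single pair, and its size should be read with care, since the same assay holds widely separated values for one compound: the several entries of compound 3 in this assay, 3000 nM; 100 nM (2 entries)

The compounds shown leave open whether the stronger reading follows the dimethylamino group itself or simply the loss of the 4-chlorophenyl ring, a question that a plain propyl chain, or a morpholine on the same chain, would speak to. Going by these compounds, how the length of the chain bears on the number is also open, for a shorter ethyl or a longer butyl link to the same dimethylamino group.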